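Replacing 1H-indol-3-yl with 4-chlorophenyl on the shared core

The source may report more compounds than this note shows. Statements on the series, on what has been measured and on what is new or still open speak of the compounds shown alone.

Compound 1 `COc1cc(-c2ccnc3cc(-c4ccc(F)cc4)nn23)cc(OC)c1OC` gives 3800 nM
Compound 2 `COc1cc(-c2ccnc3cc(-c4cn(CO)c5ccccc45)nn23)cc(OC)c1OC` gives 167 nM
Compound 3 `COc1cc(-c2ccnc3cc(-c4c[nH]c5ccccc45)nn23)cc(OC)c1OC` gives 29 nM

All three values come from a functional assay on A549 cells (Homo sapiens) for inhibition, read by CCK-8 assay, with a stated time of 48 h (a lower number here means a stronger inhibitor, a higher number a weaker inhibitor), and compound 3 has the lowest number of the three, with its steps to both others beyond the scatter. The next compound to consider is compound 4 `COc1cc(-c2ccnc3cc(-c4ccc(Cl)cc4)nn23)cc(OC)c1OC`, which has not been measured yet. Its difference from compound 3 is 4-chlorophenyl in place of 1H-indol-3-yl on an aromatic carbon and in words this puts 4-chlorophenyl in place of 1H-indol-3-yl on an aromatic carbon.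

The closest evidence is a 130-fold lower number from compound 1 to compound 3 (2.12 log units; beyond the scatter) in this assay, a large step that put 1H-indol-3-yl in place of 4-fluorophenyl at this same carbon. Compound 4 nearly reverses that change, carrying 4-chlorophenyl where compound 1 carries 4-fluorophenyl. Within the data shown here, no measured pair compares those two groups directly. The other step, a 5.8-fold lower number from compound 2 to compound 3 (0.76 log units; beyond the scatter), is modest and concerns only hydroxymethyl on an aromatic nitrogen, so it bears on this change only weakly.

A large rise in the number is therefore expected, towards a weaker inhibitor, and a 120-fold higher number from compound 3 to compound 4 (2.08 log units; beyond the scatter) is the estimated step. For compound 4 the estimated value is 3500 nM within an expected range from 1200 nM to 10000 nM.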

Compound 4, half-maximal inhibitory concentration: 3070 nM
Estimate against measurement, compound 4: 1.1-fold (0.06 log units) above; low and high end bracket the measured number.
By their numbers in this assay, from the lowest: compound 3; then compound 2; then compounds 4 and 1 (each within the scatter of the next).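

In this assay the change to 4-chlorophenyl brings a 110-fold higher number from compound 3 to compound 4 (2.02 log units; beyond the scatter), so the large penalty for giving up 1H-indol-3-yl at this carbon is not peculiar to the fluoro compound but appears with a second halogen-bearing phenyl as well. The direct comparison of the two halogens, chloro in place of fluoro, gives a 1.2-fold lower number from compound 1 to compound 4 (0.09 log units; within the scatter), which means that this swap makes no discernible difference and recovers none of the ground held by compound 3. No measurement shown here explains why the 1H-indol-3-yl group and these two phenyl groups stand so far apart.

On these data alone, it remains open whether any phenyl group at this carbon can come close to compound 3, for example one carrying an amine or a carboxylic acid in place of the halogen. As far as these compounds go, on the 1H-indol-3-yl side, only hydrogen and hydroxymethyl appear on the aromatic nitrogen, so it also remains unknown how a methyl group or a longer chain there would compare.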